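The compounds below may be only part of what the source reports. "The series", "measured", "known", "first", "only" and "open" are said of these compounds alone.

Working notes on the series. The parent is compound 1 `CC1=CC[C@H](C(C)(C)NC(=S)N/N=C/c2ccccc2)CC1`; in a functional assay on 786-0 cells (Homo sapiens) for inhibition, read by sulforhodamine B assay, with a stated time of 48 h (a lower number here means a stronger inhibitor of growth, a higher number a weaker inhibitor of growth), compound 1 gives 9900 nM. Among the two numbers in hand it is the higher one, the nearest being compound 2 `COc1ccc(/C=N/NC(=S)NC(C)(C)[C@H]2CC=C(C)CC2)cc1`, which in this assay gives 8900 nM; the step of a 1.1-fold lower number from compound 1 to compound 2 (0.05 log units; within the scatter) on introducing methoxy in place of hydrogen on an aromatic carbon falls within the scatter. Compound 3 `CC1=CC[C@H](C(C)(C)NC(=S)N/N=C/c2ccc(F)cc2)CC1` gives > 100000 nM in this assay, which is a limit of the assay rather than a number, as noted in the limit of > 100000 nM in this assay, at which 1 of the 3 values shown sits. The step of an at least 10-fold higher number from compound 1 to compound 3 (1.00 log units; beyond the scatter) for fluoro in place of hydrogen on an aromatic carbon is beyond the scatter, as is an at least 11-fold higher number from compound 2 to compound 3 (1.05 log units; beyond the scatter).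

The next member is compound 4 `CC1=CC[C@H](C(C)(C)NC(=S)N/N=C/c2ccc(Cl)cc2)CC1`, which differs from compound 1 by chloro in place of hydrogen on an aromatic carbon. The step that bears most directly on it is that to compound 3, since it alters the same hydrogen at the same place of the shared core and gave an at least 10-fold higher number from compound 1 to compound 3 (1.00 log units; beyond the scatter); the methoxy step a 1.1-fold lower number from compound 1 to compound 2 (0.05 log units; within the scatter) left the number unchanged. The expectation is therefore a step toward a higher number in this assay, of uncertain size and with a real chance of only a limit. Compound 4 is estimated at 30000 nM, range 8000 nM to 120000 nM, an expected step of a 3.0-fold higher number from compound 1 to compound 4 (0.48 log units; beyond the scatter).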

Compound 4, concentration for 50% growth inhibition: 74900 nM
Beside the measured number, compound 4's estimate is 2.5-fold (0.40 log units) below it; the range from low to high includes it.
By their numbers in this assay, from the lowest: compounds 2 and 1 (each within the scatter of the next); then compound 4. At a limit, above all of these: compound 3.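

In this assay, a second halogen on the aromatic carbon para to a large group now gives a measured number rather than a limit, so the loss of growth inhibition on this change has a size: a 7.6-fold higher number from compound 1 to compound 4 (0.88 log units; beyond the scatter). Set against the methoxy member, the same place gives an 8.4-fold higher number from compound 2 to compound 4 (0.93 log units; beyond the scatter), so among the four compounds both halogens stand apart from hydrogen and methoxy, and neither goes against this. The chloro-for-fluoro step reads an at least 1.3-fold lower number from compound 3 to compound 4 (0.12 log units; that floor lies within the scatter), and with compound 3 held at a limit of the assay, no order between the two halogens follows: the limit of > 100000 nM in this assay, at which 1 of the 4 values shown sits.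

Still open is whether the loss belongs to halogens as such or to other small groups at this place as well, since only hydrogen, methoxy, fluoro and chloro are shown there; a bromo, a methyl, a hydroxyl, a nitrile or an amine at the same carbon would separate these readings. Also open, going by these compounds, is whether the effect of chloro holds when the rest of the shared core changes, for instance with a longer chain in place of the methyl groups.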